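Dropping the acetyl from a chromene-type anti-inflammatory scaffold

The source may hold more compounds than are shown below. What is called first, only, known or untested is meant among the compounds shown, and "the series" means these compounds.

Measured compounds:
Compound 1, `COc1ccc2c(c1)OC(c1cc(OC)c(OC)c(OC)c1)C(C(C)=O)=C2`: 14100 nM
Compound 2, `COc1ccc2c(c1)OC(c1cc(OC)c(OC)c(OC)c1)C(C(N)=O)=C2`: > 50000 nM
Compound 3, `CCCCNC(=O)C1=Cc2ccc(OC)cc2OC1c1cc(OC)c(OC)c(OC)c1`: 25500 nM

In a functional assay for inhibition of nuclear factor NF-kappa-B complex (Homo sapiens) (on this read-out higher numbers stand for weaker inhibition and lower numbers for stronger inhibition), compound 1 gives the lowest of the two numbers shown, 14100 nM, although its gap to compound 3 is within the scatter. Compound 2 reaches only the assay limit, > 50000 nM. Compound 3 gives 25500 nM in this assay.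

Compound 4, `COc1ccc2c(c1)OC(c1cc(OC)c(OC)c(OC)c1)C=C2`, differs from compound 1 by hydrogen in place of acetyl on a double-bonded ring carbon. Within the data shown here, no measured step removes the carbonyl group altogether; the two related steps alter only what sits on that carbonyl. The step of an at least 3.5-fold higher number from compound 1 to compound 2 (0.54 log units; beyond the scatter) weakened inhibition, whereas a 1.8-fold higher number from compound 1 to compound 3 (0.26 log units; within the scatter) stayed within the scatter. Both retained the carbonyl, so the loss of the whole acetyl is a larger departure than either. A step of about a 2.0-fold higher number from compound 1 to compound 4 (0.30 log units; within the scatter) toward weaker inhibition is expected, with a real chance that only a limit is reported. Compound 4 is therefore estimated at 28000 nM, in the range 8000 nM to 90000 nM.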

Compound 4, half-maximal inhibitory concentration: 17700 nM
Estimate against measurement, compound 4: 1.6-fold (0.20 log units) above; measured number inside the range.
By their numbers in this assay, from the lowest: compounds 1, 4 and 3 (each within the scatter of the next). At a limit, above all of these: compound 2.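

In this assay, the carbonyl kept by both earlier changes turns out not to be needed at this double-bonded ring carbon: with hydrogen in place of the whole acetyl, the result is a 1.3-fold higher number from compound 1 to compound 4 (0.10 log units; within the scatter). Hydrogen in place of butylcarbamoyl likewise gives a 1.4-fold lower number from compound 3 to compound 4 (0.16 log units; within the scatter), so these three substituent states cannot be told apart here. The carbamoyl alone stands apart, with an at least 2.8-fold lower number from compound 2 to compound 4 (0.45 log units; beyond the scatter), and that step is only a floor because its starting value is a limit: the limit of > 50000 nM in this assay, at which 1 of the 4 values shown sits.

The compounds shown leave open whether a carboxylic acid, a methyl ester or an aminomethyl group on this carbon would move the number beyond the scatter of the hydrogen compound. They also leave open whether a hydroxyl in place of a methoxy group elsewhere on the shared core would do so.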